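Cytotoxicity of Three Diamines and an Unmeasured Fourth

The source may hold more compounds than are shown below. What is called first, only, known or untested is meant among the compounds shown, and "the series" means these compounds.

Compound 1 `CN(C)C12CC(c3ccccc3)C(CN(CCCN3CCCCC3)C1)C(c1ccccc1)C2`: 1750 nM
Compound 2 `CCN(CC)CCCN1CC2C(c3ccccc3)CC(N(C)C)(CC2c2ccccc2)C1`: 3270 nM
Compound 3 `CN(C)C12CCN(CCN3CCCCC3)C(C(c3ccccc3)C1)C(c1ccccc1)C2`: 135000 nM

All three were measured in an ADME assay on L6 cells (Rattus norvegicus) for cytotoxicity, read by resazurin assay, with a stated time of 72 h; on this read-out lower numbers stand for stronger inhibition and higher numbers for weaker inhibition. Compound 1 and compound 2 share a core and differ in a single place: diethylamino in place of piperidin-1-yl on a saturated chain carbon, three bonds along the chain from an amine nitrogen in a ring. That step reads a 1.9-fold higher number from compound 1 to compound 2 (0.27 log units; within the scatter). Compound 3 stands well apart from both, beyond the scatter in each case; the difference between its core and the core of compound 1 is not broken down here.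

Compound 4 `CCN(CC)CCN1CCC2(N(C)C)CC(c3ccccc3)C1C(c1ccccc1)C2` has not yet been measured. It differs from compound 3 by diethylamino in place of piperidin-1-yl on a saturated chain carbon, two bonds along the chain from an amine nitrogen in a ring. Within the data shown here, this is the same kind of change as the one from compound 1 to compound 2, though not identical in place: there the group sits three bonds along the chain from an amine nitrogen in a ring, here two bonds along. Since the earlier step stayed within the scatter, compound 4 is expected to remain close to compound 3. Compound 4 is expected to show the step of a 1.5-fold higher number from compound 3 to compound 4 (0.17 log units; within the scatter). This rests on the number of compound 3, 135000 nM, and on the earlier step of a 1.9-fold higher number from compound 1 to compound 2 (0.27 log units; within the scatter). The estimate for compound 4 is 200000 nM, between 70000 nM and 550000 nM.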

Compound 4, half-maximal inhibitory concentration: 101000 nM
The estimate for compound 4 lay 2.0-fold (0.30 log units) above the measured number, and the stated range covers the measured number.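

In this assay, putting diethylamino in place of piperidin-1-yl gives a 1.3-fold lower number from compound 3 to compound 4 (0.13 log units; within the scatter). The change thus stays within the usual scatter on this second core as well, and the two cores cannot be told apart in how they respond to it: the same change on two cores in this assay, a 1.9-fold higher number (0.27 log units; within the scatter) from compound 1 to compound 2 and a 1.3-fold lower number (0.13 log units; within the scatter) from compound 3 to compound 4, 2.5-fold (0.40 log units) apart, within the scatter of two such steps. Among these compounds, this shows only that the swap carried across these two pairs without a step that could be separated from the scatter; it does not show that the swap would behave the same way on any further core, and the two pairs also differ in where the group sits, three bonds along the chain in one and two bonds along in the other.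

The compounds shown leave open whether a different amine at this place, such as morpholin-4-yl or dimethylamino, would stay as close to its piperidin-1-yl partner. They also leave open how either amine would read on a longer chain.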